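The source may report more compounds than this note shows. Statements on the series, on what has been measured and on what is new or still open speak of the compounds shown alone.

Compound 1 `O=Cc1ccc(-c2cn3ccnc3c(-c3ccc4ncn(C5CCCCC5)c4c3)n2)cc1` and compound 2 `Brc1ccc(-c2cn3ccnc3c(-c3ccc4ncn(C5CCCCC5)c4c3)n2)cc1` share one core and differ only in the group on the pendant phenyl ring. In a functional assay on SF-539 cells (Homo sapiens) for inhibition, read by sulforhodamine B assay, with a stated time of 48 h, tested at 10 uM (on this read-out higher numbers stand for more inhibition at the one concentration tested (going by the name of the read-out) and lower numbers for less inhibition), compound 1 gives 31.5% and compound 2 gives 24.4%. Going by the values given here, the only measured step is a number 7.1 percentage points lower from compound 1 to compound 2 (within the scatter); compound 2 therefore holds the smaller of the two numbers, but the gap to compound 1 does not exceed the scatter, so the two cannot be ordered on this evidence.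

Compound 3 `COc1ccccc1-c1cn2ccnc2c(-c2ccc3ncn(C4CCCCC4)c3c2)n1` is not yet measured. Relative to compound 2 the change is 2-methoxyphenyl in place of 4-bromophenyl on an aromatic carbon. Among the compounds with values here, no measured step covers this exchange: the one step known, from the formyl to the bromo analogue, was within the scatter and concerned a different substituent at a different position of that ring. Within the data shown here, with a single step of that size as the only guide, no movement beyond the scatter is expected from compound 2 to compound 3, so the estimated step is a number 2.6 percentage points higher from compound 2 to compound 3 (within the scatter). For compound 3 the expected value in this assay is therefore 27%, with a range from 8% to 48% reflecting the thin basis.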

Compound 3, a percentage reported as inhibition, at one concentration (the size of the read-out at that concentration, not a potency): 8.07%
Compound 3: the middle estimate sits 18.9 percentage points above what was measured; the measured number falls inside the stated range.
By their numbers in this assay, from the lowest: compound 3; then compounds 2 and 1 (each within the scatter of the next).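

In this assay, going by these compounds alone, the exchange at this aromatic carbon of the shared core gives a number 16.3 percentage points lower from compound 2 to compound 3 (beyond the scatter), and the comparison with the formyl analogue gives a number 23.4 percentage points lower from compound 1 to compound 3 (beyond the scatter); these are the first steps that lie beyond the scatter. The group carried at this position therefore does register in the read-out: the 4-bromophenyl and 4-formylphenyl compounds stay within the scatter of each other, while the 2-methoxyphenyl compound 3 stands apart from both with the lowest number of the three. The exchange alters both the substituent and its place on the phenyl ring, and no measurement available here accounts for the lower number.

From the compounds shown here alone, it remains open whether the lower number goes with the methoxy group itself or with its place on the ring, a split that a 4-methoxyphenyl or a 2-bromophenyl analogue would resolve. Also open, going by these compounds, is how a phenyl ring carrying an amine or a carboxylic acid would read, and whether any group at this position can raise the number well beyond that of compound 1.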